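The source may report more compounds than this note shows. Statements on the series, on what has been measured and on what is new or still open speak of the compounds shown alone.

Measured so far:
- compound 1 `Cc1nc(-c2ccccc2)c(C(=O)N2CCN(c3cccc(C)c3C)CC2)o1`: 35 nM
- compound 2 `COc1cc(OC)cc(N2CCN(C(=O)c3oc(C)nc3-c3ccccc3)CC2)c1`: 19.2 nM

Going by the values given here, in a functional assay on HL-60 cells (Homo sapiens) for inhibition, read by MTT assay, with a stated time of 72 h (on this read-out lower numbers stand for stronger inhibition and higher numbers for weaker inhibition), compound 2 gives 19.2 nM and cannot be separated from compound 1, as the only measured step is a 1.8-fold lower number from compound 1 to compound 2 (0.26 log units; within the scatter). That step swaps one aryl group for another on an amine nitrogen in a ring, the same place that changes next.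

Compound 3 `Cc1nc(-c2ccccc2)c(C(=O)N2CCN(c3cccc(C#N)c3)CC2)o1` is still unmeasured. Its change is 3-cyanophenyl in place of 3,5-dimethoxyphenyl on an amine nitrogen in a ring. Among the compounds with values here, no measured compound carries 3-cyanophenyl, so a single small step is the only guide, and no shift beyond the scatter is expected in this assay. The expected change is a 1.6-fold higher number from compound 2 to compound 3 (0.19 log units; within the scatter). For compound 3 the estimated value is 30 nM, with an expected range from 8 nM to 120 nM.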

Compound 3, half-maximal inhibitory concentration: 39.6 nM
The estimate for compound 3 lay 1.3-fold (0.12 log units) below the measured number; measured number inside the range.
By their numbers in this assay, from the lowest: compounds 2, 1 and 3 (each within the scatter of the next, the first and the last beyond it).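

In this assay, this position on the amine nitrogen in a ring now shows its first step beyond the scatter: 3-cyanophenyl in place of 3,5-dimethoxyphenyl gives a 2.1-fold higher number from compound 2 to compound 3 (0.31 log units; beyond the scatter) and the step is modest. Against 2,3-dimethylphenyl, the same 3-cyanophenyl group gives a 1.1-fold higher number from compound 1 to compound 3 (0.05 log units; within the scatter) and the two compounds cannot be separated. Among these three aryl groups, only the 3,5-dimethoxyphenyl and 3-cyanophenyl pair comes apart, and only narrowly.

Still open, going by these compounds, is whether a group of another kind on this nitrogen, such as a longer alkyl chain, or an amine or carboxylic acid on the phenyl ring, would move the number further. No available measurement bears on what lies behind the modest step.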